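The compounds below may be only part of what the source reports. "The series", "measured", "known", "first", "only" and "open" are said of these compounds alone.

compound 1 `COc1cc(OCc2ccnc(N)n2)cc2sc(N[C@H]3CCCC[C@@H]3O)nc12` gives 20 mL/min/kg
compound 2 `COc1cc(OCc2ccnc(N)n2)c(Cl)c2sc(N[C@H]3CCCC[C@@H]3O)nc12` gives 43 mL/min/kg

In an ADME assay on microsomes from liver (Rattus norvegicus, strain Sprague-Dawley) for pharmacokinetics, read by LC-MS, using NADPH, with a stated time of 45 min, tested at 1 uM (on this read-out lower numbers stand for slow clearance and higher numbers for fast clearance), compound 2 has the higher number of the two. Compound 3 `COc1cc(OCc2ccnc(Nc3cnn(C)c3)n2)c(Cl)c2sc(N[C@H]3CCCC[C@@H]3O)nc12` carries one change from compound 2: 1-methyl-1H-pyrazol-4-yl in place of hydrogen on a nitrogen on an aromatic ring. Within the data shown here, the only measured step (a 2.2-fold higher number from compound 1 to compound 2 (0.33 log units; beyond the scatter)) was modest and concerns chloro in place of hydrogen, a different change, so it bears only loosely on this one. Among the measured compounds shown here, no measured step tests the new group. Only a small upward step is expected (a 1.2-fold higher number from compound 2 to compound 3 (0.07 log units; within the scatter)). Compound 3 is expected at 50 mL/min/kg with a range from 25 mL/min/kg to 90 mL/min/kg in this estimate.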

Compound 3, clearance: 124 mL/min/kg
Estimate against measurement, compound 3: 2.5-fold (0.39 log units) below; measured number outside the range, above it.
By their numbers in this assay, from the lowest: compound 1; then compound 2; then compound 3.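

In this assay the change from amino to (1-methyl-1H-pyrazol-4-yl)amino gives a 2.9-fold higher number from compound 2 to compound 3 (0.46 log units; beyond the scatter) and so shows that clearance responds to a substituent on this nitrogen on an aromatic ring. The earlier compounds shown here differed only by chloro in place of hydrogen on an aromatic carbon, so they did not test this nitrogen. No available evidence accounts for the rise. Still open, going by these compounds, is whether a plain methyl group or a phenyl ring on this nitrogen would raise the number as well. Also open, on these data alone, is whether 1-methyl-1H-pyrazol-4-yl would act the same way without the chloro.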